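The compounds below may be only part of what the source reports. "The series", "measured", "known", "first", "only" and "open" are said of these compounds alone.

Compound 1 `C=C(C)CCOc1c(OC)cc(/C=C/CO)cc1OC` is the starting point of this step. In a functional assay on OE21 cells (Homo sapiens) for cytotoxicity, read by MTT assay, with a stated time of 72 h (a higher number here means a weaker inhibitor, a lower number a stronger inhibitor), compound 1 gives > 100000 nM, which is a limit of the assay and not a number. Compound 1 therefore stands only at the limit of > 100000 nM in this assay, at which 1 of the 2 values shown sits, with no measured potency to place it against. Among the compounds with values here, compound 2 `COc1cc(/C=C/CO)ccc1OC/C=C(\C)CCC=C(C)C` shares the core and is the only other compound measured so far; in this assay compound 2 gives 23000 nM. Within the data shown here, no step between measured compounds that differ in a single place is available, so nothing sizes the effect of any one change.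

Compound 3 `COc1cc(/C=C/CO)cc(OC)c1O` is not yet measured. It differs from compound 1 by hydrogen in place of 3-methylbut-3-en-1-yl on an oxygen on an aromatic ring. With compound 1 resting at a limit, the step that the limit leaves unreadable from compound 1 to compound 3 is expected to stay within the usual scatter, most likely returning a limit again rather than a number. The estimate for compound 3 in this assay is 150000 nM, with a range from 40000 nM to 500000 nM.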

Compound 3, half-maximal inhibitory concentration: 80000 nM
Estimate against measurement, compound 3: 1.9-fold (0.27 log units) above; low and high end bracket the measured number.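

In this assay compound 3 gives 80000 nM, so with hydroxy in place of (3-methylbut-3-en-1-yl)oxy the series has a measured number on this core, and the 3-methylbut-3-en-1-yl group is not needed to obtain one. Compound 1 gives > 100000 nM, which is a limit of the assay and not a number. The change therefore reads only as an at least 1.2-fold lower number from compound 1 to compound 3 (0.09 log units; that floor lies within the scatter), and its true size stays open: the limit of > 100000 nM in this assay, at which 1 of the 3 values shown sits.

The compounds shown do not tell how a short ethyl or a benzyl group on this oxygen would compare with the free hydroxy of compound 3. Also open, on these data alone, is whether a chain ending in an amine or a carboxylic acid at this place would shift the number beyond the scatter.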